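Methoxy to hydroxy in the difluoroanilide series

The source may report more compounds than this note shows. Statements on the series, on what has been measured and on what is new or still open speak of the compounds shown alone.

Values in a functional assay on KYSE-70 cells for antiproliferative activity against KYSE-70 cell line (Homo sapiens), read by MTT assay, with a stated time of 72 h (a lower number here means a stronger inhibitor, a higher number a weaker inhibitor), for the measured compounds:
- compound 1 `COc1ccc(-c2ccc3c(C(=O)Nc4cccc(F)c4)cc(=O)[nH]c3c2)cc1` gives > 20000 nM (a limit)
- compound 2 `COc1cccc2c(C(=O)Nc3cc(F)cc(F)c3)cc(=O)[nH]c12` gives > 20000 nM (a limit)

Compound 2 stands at a limit in this assay and gives no number: its entry is > 20000 nM and nothing finer. Among the measured compounds shown here, the whole picture so far is the limit of > 20000 nM in this assay, at which 2 of the 2 values shown sit, and no measured step exists between the two compounds.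

Compound 3 `O=C(Nc1cc(F)cc(F)c1)c1cc(=O)[nH]c2c(O)cccc12` differs from compound 2 by hydrogen in place of methyl on an oxygen on an aromatic ring with hydrogen in place of methyl on an oxygen on an aromatic ring, methoxy to hydroxy.

For the measured compounds named here, with no measured step to go on, no change beyond the scatter is expected in this assay in either direction. The expected step is a number no higher from compound 2 to compound 3 (the limit leaves the size open) and it remains a rough estimate. For compound 3 the estimated value is 20000 nM with an expected range from 6000 nM to 40000 nM and a further limit is the likeliest report.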

Compound 3, half-maximal inhibitory concentration: > 20000 nM
Compound 3: a limit, no number (the forecaster's own chance of this, stated with the estimate: 65%); the middle value lies on the limit itself.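

In this assay no step can be read from compound 2 to compound 3, because both entries are limits: the limit of > 20000 nM in this assay, at which 3 of the 3 values shown sit.

The compounds shown leave open how methoxy and hydroxy compare in a compound of this series that gives a number rather than a limit.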